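Fluoro in place of methoxy on the phenol ring

This account rests on a few compounds, and the source may have more. Where it says the series, first, only, none or still open, it means among the compounds named here.

Measured compounds in a functional assay, with a stated time of 30 min; a lower number here means a stronger inhibitor, a higher number a weaker inhibitor:
compound 1 `Cc1cccc(/C=N/c2ccc(OCc3ccccc3)cc2)c1O`: > 200000 nM
compound 2 `Oc1ccc(O)c(/C=N/c2ccc(OCc3ccccc3)cc2)c1`: 21300 nM
compound 3 `COc1ccc(O)c(/C=N/c2ccc(OCc3ccccc3)cc2)c1`: > 200000 nM

Compound 3 `COc1ccc(O)c(/C=N/c2ccc(OCc3ccccc3)cc2)c1` sits at the assay's limit; its value in this assay is a limit and not a number, and the limit of > 200000 nM in this assay, at which 2 of the 3 values shown sit, shows where it stands. Within the data shown here, compound 2 is the only member of the set with a numerical value, and the step of an at least 9.3-fold higher number from compound 2 to compound 3 (0.97 log units; beyond the scatter) shows that capping the hydroxy group as a methyl ether costs at least that much; the step of an at least 9.3-fold lower number from compound 1 to compound 2 (0.97 log units; beyond the scatter) runs the other way. Compound 4 `Oc1ccc(F)cc1/C=N/c1ccc(OCc2ccccc2)cc1` carries fluoro in place of methoxy on an aromatic carbon. Neither measured step speaks directly to a fluoro group, so the expectation for compound 4 remains wide: it is estimated at 120000 nM (range 25000 nM to 300000 nM), which means an expected step of an at least 1.6-fold lower number from compound 3 to compound 4 (0.22 log units; that floor lies within the scatter).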

Compound 4, half-maximal inhibitory concentration: > 200000 nM
Compound 4 was reported as a limit; the forecaster's own chance of this, stated with the estimate: 45%; at least 1.6-fold (0.22 log units) between middle value and limit.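

In this assay compound 4 also gives a limit and not a number: the limit of > 200000 nM in this assay, at which 3 of the 4 values shown sit. Fluoro in place of the hydroxy group gives an at least 9.3-fold higher number from compound 2 to compound 4 (0.97 log units; beyond the scatter), so among hydroxy, methoxy and fluoro at this position, para to a hydroxy group, only hydroxy gives a numerical value. The steps from compound 3 and from compound 1 to compound 4 cannot be read, since both ends are limits.

From the compounds shown here alone, whether an amine or a carboxylic acid at this position would also give a numerical value stays open. Going by these compounds, how compound 3 and compound 4 rank against each other also stays open.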